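Replacing the oxolane amide with a methylaminoethyl amide

The compounds below may be only part of what the source reports. "The series", "measured", "known", "first", "only" and "open" are said of these compounds alone.

Measured compounds:
compound 1, `COc1cccc2c1c(NS(=O)(=O)c1ccc(Cl)s1)nn2Cc1cccc(CNC(=O)C2COC2)c1`, giving a limit in a physicochemical assay for solubility, read by chemiluminescence, measured as kinetic solubility (a higher number here means a more soluble compound, a lower number a less soluble compound), of >= 173 ug/mL.
compound 2, `COc1cccc2c1c(NS(=O)(=O)c1ccc(Cl)s1)nn2Cc1cccc(CNC(=O)C2CCO2)c1`, giving 124 ug/mL.
compound 3, `COc1cccc2c1c(NS(=O)(=O)c1ccc(Cl)s1)nn2Cc1cccc(CNC(=O)C2CCCO2)c1`, giving a limit of >= 153 ug/mL.

Going by the values given here, compound 3 therefore stands at a limit, not a number, and so does compound 1; compound 2 is the only one with a read value. The steps among them are small: an at least 1.3-fold lower number from compound 1 to compound 2 (0.14 log units; that floor lies within the scatter), an at least 1.2-fold higher number from compound 2 to compound 3 (0.09 log units; that floor lies within the scatter), and a step that the two limits leave unreadable from compound 1 to compound 3.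

Compound 4, `CN[C@H](C)C(=O)NCc1cccc(Cn2nc(NS(=O)(=O)c3ccc(Cl)s3)c3c(OC)cccc32)c1`, differs from compound 3 by 1-(methylamino)ethyl in place of oxolan-2-yl on a carbonyl carbon. Among the compounds with values here, none of the measured steps touches such a change; they only compare cyclic ethers, and two of them end at limits the limit of >= 153 ug/mL in this assay, at which 1 of the 3 values shown sits (the limit of >= 173 ug/mL in this assay, at which 1 of the 3 values shown sits). He therefore expects no step beyond the scatter, giving a step that the limit leaves unreadable from compound 3 to compound 4. His estimate for compound 4 is 170 ug/mL, within 90 ug/mL to 300 ug/mL.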

Compound 4, solubility: 191 ug/mL
The estimate for compound 4 lay 1.1-fold (0.05 log units) below the measured number; the range from low to high includes it.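

Going by these compounds alone, on this carbonyl carbon, the earlier compounds compared only cyclic ethers, whereas compound 4 carries 1-(methylamino)ethyl, an open group with no ring and a hydrogen-bond donor. In this assay, within the data shown here, the one readable step for this change is a 1.5-fold higher number from compound 2 to compound 4 (0.19 log units; within the scatter). The steps from compound 1 and from compound 3 to compound 4 cannot be read, for compound 1 and compound 3 stand at limits.

As far as these compounds go, the opposite stereocentre of 1-(methylamino)ethyl remains open. So does what a tertiary dimethylamino group, a longer amine chain or a carboxylic acid would give at this place.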